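Shortening the Amine Chain on a Small Quinone Core

A few compounds are considered here, and "the series" means these few. Any claim that something is new, unique, unknown or untested is made for them only; others in the source may bear on it.

Compound 1, with the structure `CCNC1=CC(=O)C=C(C(C)(C)C)C1=O`, carries an ethylamino group on its quinone core. Within the data shown here, in an ADME assay on HaCaT cells (Homo sapiens) for cytotoxicity, read by MTT assay, with a stated time of 72 h (a higher number here means a weaker inhibitor, a lower number a stronger inhibitor), compound 1 gives 30000 nM, the higher of the two plain numbers measured so far. Compound 3, `CCCCNC1=CC(=O)C=C(C[C@]2(C)[C@@H](C)CC[C@]3(C)C(C)=CCC[C@@H]23)C1=O`, gives 16000 nM in this assay; the gap between compound 3 and compound 1 lies within the scatter, so the two read as alike. For compound 2, `CCCCNC1=CC(=O)C(C[C@]2(C)[C@@H](C)CC[C@]3(C)C(C)=CCC[C@@H]23)=CC1=O`, the result in this assay is a limit, > 100000 nM, rather than a number. This is the limit of > 100000 nM in this assay, at which 1 of the 3 values shown sits.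

Compound 4, `CNC1=CC(=O)C=C(C(C)(C)C)C1=O`, is the next compound to be measured. It differs from compound 1 in a single place: hydrogen in place of methyl on a saturated chain carbon bound to an amine nitrogen. Among the measured compounds shown here, no measured pair shows exactly this change, so the expectation rests on how little the numbers spread here, since compound 1 at 30000 nM and compound 3 at 16000 nM sit within the scatter of one another despite a much larger change in structure. The step from compound 1 to compound 4 is therefore expected to be a 1.2-fold higher number from compound 1 to compound 4 (0.07 log units; within the scatter), not beyond the scatter in either direction. Compound 4 is expected to give about 35000 nM in this assay, most likely between 12000 nM and 100000 nM.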

Compound 4, half-maximal inhibitory concentration: 10000 nM
The estimate for compound 4 lay 3.5-fold (0.54 log units) above the measured number; the whole stated range lies above it.
By their numbers in this assay, from the lowest: compounds 4, 3 and 1 (each within the scatter of the next, the first and the last beyond it). At a limit, above all of these: compound 2.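

Going from ethylamino to methylamino on the shared core gives the only reading of a single change in this assay: a 3.0-fold lower number from compound 1 to compound 4 (0.48 log units; beyond the scatter). The earlier compounds shown here differ from one another in more than one place, so they could not show what this one position does on its own. Here, removing one methyl from the saturated chain carbon bound to an amine nitrogen is enough to carry the number beyond the scatter, though the step is modest. None of the data shown offers an explanation for this shift.

A single step marks only two points along this chain, so it cannot establish a trend: a propyl chain or an unsubstituted amine at the same place could continue the direction seen here, or break from it. From the compounds shown here alone, it also remains open whether the same change from ethylamino to methylamino would give a similar step on a different core, such as the larger one carried by compound 3.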